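Chloro for methyl ortho to the anilide nitrogen

This account rests on a few compounds, and the source may have more. Where it says the series, first, only, none or still open, it means among the compounds named here.

Working notes on a small set of arylbenzothiazoles tested in a functional assay on MCF7 cells (Homo sapiens) for cytotoxicity; on this read-out higher numbers stand for weaker inhibition and lower numbers for stronger inhibition.

Compound 1 `Nc1ccc(-c2nc3c(O)cccc3s2)cc1Cl` carries a chloro group and a free amino group on the pendant ring; in this assay compound 1 gives 61400 nM. Compound 3 `Cc1cc(-c2nc3c(O)cccc3s2)ccc1N` is its methyl counterpart. For compound 3 in this assay only a limit is recorded, > 100000 nM. The change between them, (chloro in place of methyl on an aromatic carbon), gives an at least 1.6-fold lower number from compound 3 to compound 1 (0.21 log units; that floor lies within the scatter), a step whose floor is set by the limit of > 100000 nM in this assay, at which 1 of the 3 values shown sits.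

Compound 2 `CC(=O)Nc1ccc(-c2nc3ccc(O)cc3s2)cc1C` has an acetamido group in place of the amino group and a different placement of the hydroxyl on the shared core; in this assay compound 2 gives 46100 nM. The values of compound 1 and compound 2 lie within the scatter of each other. The difference between the cores of compound 2 and compound 3 is not broken down here.

Compound 4 `CC(=O)Nc1ccc(-c2nc3ccc(O)cc3s2)cc1Cl`, not yet measured, is related to compound 2 by chloro in place of methyl on an aromatic carbon. This is the same kind of change as that from compound 3 to compound 1, but not the same: there the chloro sits ortho to an amino group (1 heavy atom), here ortho to an acetamido group (4 heavy atoms). Going by the measured step, compound 4 is expected to show a 1.5-fold lower number from compound 2 to compound 4 (0.19 log units; within the scatter) in this assay. That expectation rests on the step from compound 3 to compound 1 and on the value of compound 2, 46100 nM. The estimate for compound 4 is 30000 nM, with a range from 12000 nM to 80000 nM.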

Compound 4, half-maximal inhibitory concentration: 71200 nM
Estimate against measurement, compound 4: 2.4-fold (0.38 log units) below, within the range that was stated.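

In this assay, chloro in place of methyl on an aromatic carbon, ortho to an acetamido group, gives a 1.5-fold higher number from compound 2 to compound 4 (0.19 log units; within the scatter), so on this core the change stays within the usual scatter. Set beside the step on the other core, the result gives no firm reading of whether the change behaves differently from one core to the other: the same change on two cores in this assay, an at least 1.6-fold lower number (0.21 log units; that floor lies within the scatter) from compound 3 to compound 1 and a 1.5-fold higher number (0.19 log units; within the scatter) from compound 2 to compound 4; the limit leaves it open whether they differ. The pair of steps therefore shows neither that the change carries across these cores nor that it fails to, and one side of the comparison remains tied to a limit, which is not a number: the limit of > 100000 nM in this assay, at which 1 of the 4 values shown sits.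

Compound 2 and compound 3 differ in both the group on the pendant nitrogen and the placement of the hydroxyl on the core, as do compound 1 and compound 4, so the compounds shown do not separate these two differences. Also open, on these data alone, is whether fluoro, bromo, methoxy or trifluoromethyl in the same place, or a longer acyl chain in place of the acetamido group, would give a step beyond the scatter on either core.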